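Swapping a pyridyl ring for a hydroxyphenyl ring

The compounds below may be only part of what the source reports. "The series", "measured", "known", "first", "only" and "open" are said of these compounds alone.

Measured compounds:
- compound 1 `CC(Oc1ccccc1-c1ccncc1)C1=NCCN1`: 1450 nM
- compound 2 `CC(Nc1ccccc1-c1ccccc1)C1=NCCN1`: 708 nM

Of the compounds shown here, two have been measured in an assay on CHO cells for displacement of a labelled ligand from Alpha-2C adrenergic receptor (Homo sapiens); on this read-out lower numbers stand for stronger inhibition and higher numbers for weaker inhibition. Compound 1 `CC(Oc1ccccc1-c1ccncc1)C1=NCCN1` gives 1450 nM in this assay, the higher of the two numbers, and compound 2 `CC(Nc1ccccc1-c1ccccc1)C1=NCCN1` gives 708 nM, a number lower by a margin that lies beyond the usual scatter. Compound 2 differs from compound 1 in more than one place, so its value shows only that a related molecule can reach a lower number; it does not say which of its changes is responsible.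

Compound 3 `CC(Oc1ccccc1-c1ccc(O)cc1)C1=NCCN1` has not been measured yet. It differs from compound 1 in one place: 4-hydroxyphenyl in place of pyridin-4-yl on an aromatic carbon. The ring that enters keeps one hydrogen-bond acceptor and adds one hydrogen-bond donor.

Within the data shown here, no measured pair shows the effect of this exact change, so the expectation rests on the two values alone. In this assay compound 3 is expected to give 1000 nM, within a range from 350 nM to 3000 nM. This estimate means a step of a 1.5-fold lower number from compound 1 to compound 3 (0.16 log units; within the scatter) toward a lower number, small enough that it could fall inside the scatter.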

Compound 3, inhibition constant: 331 nM
Compound 3: the middle estimate sits 3.0-fold (0.48 log units) above what was measured, outside the stated range (below it).
By their numbers in this assay, from the lowest: compound 3; then compound 2; then compound 1.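

In this assay, the ring at this place clearly matters: 4-hydroxyphenyl in place of pyridin-4-yl gives a 4.4-fold lower number from compound 1 to compound 3 (0.64 log units; beyond the scatter), the first change in a single place whose effect can be read directly from the compounds shown. The position, on an aromatic carbon and ortho to a group of 8 heavy atoms, therefore accepts a ring of carbon only with 1 hydrogen-bond donor, and the number goes down rather than up compared with the pyridin-4-yl ring, which has 0 hydrogen-bond donors. No measurement at hand explains why this step occurs.

This single step removes the ring nitrogen and adds the hydroxyl group together, so the compounds shown cannot tell how much of the change belongs to each of the two. A plain phenyl ring at this place would separate those two changes, while a 4-methoxyphenyl or 4-aminophenyl ring would test whether the hydroxyl group itself is needed or whether another group on that ring carbon could serve equally well.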